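The source may report more compounds than this note shows. Statements on the series, on what has been measured and on what is new or still open speak of the compounds shown alone.

Compound 1 `COc1ccc(-c2cc(/C=C/C(=O)c3ccc(N)cc3)[nH]n2)cc1`: -1%
Compound 2 `COc1cc(-c2cc(/C=C/C(=O)c3ccc(Cl)c(Cl)c3)[nH]n2)cc(OC)c1OC`: 9%
Compound 3 `COc1cc(-c2cc(/C=C/C(=O)c3ccc(F)c(F)c3)[nH]n2)cc(OC)c1OC`: 9%

All three were tested in a functional assay on T47D cells (Homo sapiens) for cytotoxicity, read by sulforhodamine B assay, with a stated time of 48 h, tested at 10 uM; on this read-out higher numbers stand for a weaker effect at the one concentration tested and lower numbers for a stronger effect. In this assay compound 1 gives -1%, compound 2 gives 9% and compound 3 gives 9%. The number for compound 1 is the smallest of the three, but each of the other two sits only a little higher and within the usual scatter of it, so the three compounds cannot be told apart on these numbers.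

Compound 4 `COc1ccc(-c2cc(/C=C/C(=O)c3ccc(N)cc3)[nH]n2)cc1OC` is obtained from compound 1 by one change: methoxy in place of hydrogen on an aromatic carbon. Going by the values given here, the only measured step, no change at the digits printed from compound 2 to compound 3 (within the scatter), concerns a swap at the far end of the shared core and has no direct bearing on a change next to the existing methoxy group. Since every measured compound, with one methoxy group or with three, gives a number close to zero, the step of a number 4 percentage points higher from compound 1 to compound 4 (within the scatter) is expected to stay within the scatter. Compound 4 is therefore estimated at 3%, between -12% and 18%.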

Compound 4, a percentage reported as activity, at one concentration (the size of the read-out at that concentration, not a potency): 28%
Compound 4: the middle estimate sits 25 percentage points below what was measured, outside the stated range (above it).
By their numbers in this assay, from the lowest: compounds 1, 2 and 3 (each within the scatter of the next); then compound 4.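

Methoxy in place of hydrogen on an aromatic carbon, ortho to a methoxy group and meta to a large group, gives a number 29 percentage points higher from compound 1 to compound 4 (beyond the scatter) in this assay, which means a weaker effect at the one concentration tested. Going by these compounds alone, the only earlier step, no change at the digits printed from compound 2 to compound 3 (within the scatter), concerned a different place, so this is the first sign that the read-out responds to a change on the aromatic ring that carries the methoxy group. Nothing measured here explains why this single change weakens the effect.

As far as these compounds go, whether this weakening is particular to methoxy stays open, since a smaller hydroxy group or a longer ethoxy group at the same place could behave differently. Compound 2 and compound 3 differ from compound 4 in more than one place, so they cannot show how this change acts in other settings.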